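The compounds below may be only part of what the source reports. "The series", "measured", "known", "first", "only" and "open" are said of these compounds alone.

Measured so far:
compound 1 `COc1cc(F)ccc1-c1ccnc2[nH]c(C3CCN(CC(=O)N(C)C)CC3)cc12`: 14 uL/min
compound 2 `CC(C)n1nc(-c2ccnc3[nH]c(C4CCN(CC(=O)N(C)C)CC4)cc23)ccc1=O`: 13 uL/min

In an ADME assay on microsomes from liver (Homo sapiens) for metabolic stability (on this read-out lower numbers stand for slow clearance and higher numbers for fast clearance), compound 1 gives 14 uL/min and compound 2 gives 13 uL/min. Compound 2 holds the lowest of the two numbers, but its gap to compound 1 is within the scatter, so the two cannot be ordered. Among the measured compounds shown here, the only measured step, a 1.1-fold lower number from compound 1 to compound 2 (0.03 log units; within the scatter), exchanged the whole group on the aromatic carbon of the shared core and moved the number only within the scatter.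

Compound 3 `CC(C)n1cc(-c2ccnc3[nH]c(C4CCN(CC(=O)N(C)C)CC4)cc23)cnc1=O` is not yet measured. It differs from compound 2 as follows: a group of 10 heavy atoms (7 carbon, 2 nitrogen, 1 oxygen; one six-membered aromatic ring with 2 hetero atoms) in place of a group of 10 heavy atoms (7 carbon, 2 nitrogen, 1 oxygen; one six-membered aromatic ring with 2 hetero atoms), on an aromatic carbon. For the measured compounds named here, the step from compound 1 to compound 2 is the only one that bears on this change, and it was within the scatter; no measured step rearranges the atoms of a group of unchanged composition. The expected step from compound 2 to compound 3 in this assay is therefore a 1.1-fold higher number from compound 2 to compound 3 (0.03 log units; within the scatter), none beyond the scatter. Compound 3 is expected to give 14 uL/min, with a range from 7 uL/min to 28 uL/min.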

Compound 3, intrinsic clearance in a liver preparation (reported as CLH), per the amount of preparation that the assay uses in the Homo sapiens assay: 24 uL/min
Beside the measured number, compound 3's estimate is 1.7-fold (0.23 log units) below it, within the range that was stated.
By their numbers in the Homo sapiens assay, from the lowest: compounds 2, 1 and 3 (each within the scatter of the next).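

On this aromatic carbon, opposite the ring nitrogen, the Homo sapiens assay shows a 1.8-fold higher number from compound 2 to compound 3 (0.27 log units; within the scatter) for a rearrangement of the same atoms within the group and a 1.7-fold higher number from compound 1 to compound 3 (0.23 log units; within the scatter) against the group with the aromatic ring of carbon only. In a physicochemical assay for lipophilicity, using the shake flask method, measured as octanol-water partition, at pH 7.4 (a lower number here means a more polar compound, a higher number a more lipophilic compound), compound 2 gives 2 and compound 3 gives 0.4 and the same rearrangement amounts to a number 1.60 log units lower from compound 2 to compound 3 (beyond the scatter) with the composition of the group unchanged. Compound 3 is thus the more polar of this pair, yet its step in the Homo sapiens assay stays within the scatter, so at this position a large difference in distribution coefficient comes without a clearance step beyond the scatter: the measured distribution coefficient of compound 2, 2, and of compound 3, 0.4, a number 1.60 log units lower (beyond the scatter)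

One pair cannot show how clearance and distribution coefficient relate across the series. Open, going by these compounds, is whether an aromatic ring carrying an amine or a carboxylic acid on this aromatic carbon would separate from these compounds in the Homo sapiens assay.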